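Three inactive quinolinone amides and a fourth awaiting measurement

The compounds below may be only part of what the source reports. "The series", "measured", "known", "first", "only" and "open" are said of these compounds alone.

The study concerns a set of quinolinone carboxamides tested in a functional assay on KYSE-70 cells for antiproliferative activity against KYSE-70 cell line (Homo sapiens), read by MTT assay, with a stated time of 72 h; a lower number here means a stronger inhibitor, a higher number a weaker inhibitor. Compound 1 `O=C(Nc1ccc(F)cc1)c1cc(=O)[nH]c2cc(Br)ccc12` carries a fluoro on its aniline ring; in this assay compound 1 gives only a limit, > 20000 nM. Compound 2 `CC(C)(C)c1ccc(NC(=O)c2cc(=O)[nH]c3cc(Br)ccc23)cc1` carries a tert-butyl in the same place, and in this assay compound 2 also gives only a limit, > 20000 nM. The change between them, (fluoro in place of tert-butyl on an aromatic carbon), is therefore a step that cannot be sized: a step that the two limits leave unreadable from compound 2 to compound 1. Compound 3 `CC(C)(C)c1ccc(-c2ccc3c(C(=O)Nc4cccc(F)c4)cc(=O)[nH]c3c2)cc1` has a different core; the difference between the cores of compound 2 and compound 3 is not broken down here. In this assay compound 3 again gives only a limit, > 20000 nM. All three values thus sit at the limit of > 20000 nM in this assay, at which 3 of the 3 values shown sit.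

Compound 4 `O=C(Nc1cccc(F)c1)c1cc(=O)[nH]c2cc(-c3ccc(F)cc3)ccc12` is not yet measured. It differs from compound 3 by fluoro in place of tert-butyl on an aromatic carbon, the same change as that from compound 2 to compound 1, at the same kind of place. Since the measured version of this change could not be read, the expectation for compound 4 rests only on the fact that compound 3 sits at a limit, > 20000 nM, and that the parallel pair of compound 2 and compound 1 both sit at the limit of > 20000 nM in this assay, at which 3 of the 3 values shown sit. The step expected from compound 3 to compound 4 is a step that the limit leaves unreadable from compound 3 to compound 4, meaning compound 4 is expected to remain near the limit. Compound 4 is estimated at 25000 nM, with a likely range from 8000 nM to 60000 nM, and most probably the assay will again report only a limit.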

Compound 4, half-maximal inhibitory concentration: 3300 nM
Estimate against measurement, compound 4: 7.6-fold (0.88 log units) above; measured number below the stated range.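

In this assay, fluoro in place of tert-butyl on an aromatic carbon, para to a large group, gives an at least 6.0-fold lower number from compound 3 to compound 4 (0.78 log units; beyond the scatter), so on the core of compound 3 this change has a readable effect that lies beyond the scatter. The starting point of this step is only a limit, and the true step may be larger. The same change on the other core, going from compound 2 to compound 1, cannot be read, as both ends of that pair are limits; compound 1 stays at a limit while compound 4 does not, but this does not show that the step is smaller there, since the size of neither step is known exactly. With one sized pair and two cores that differ, the series does not show that the effect carries from one core to the other, and the data remain thin: the limit of > 20000 nM in this assay, at which 3 of the 4 values shown sit.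

Among these compounds, compound 4 is the only compound here with a number rather than a limit, so it remains open how far the 4-fluorophenyl group itself matters, compared with simply losing the tert-butyl. On these data alone, it also remains open whether an amine, a carboxylic acid or a longer chain at that place on the ring would lower the number further or raise it again.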